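The source may hold more compounds than are shown below. What is called first, only, known or untested is meant among the compounds shown, and "the series" means these compounds.

Measured so far in an ADME assay on the whole organism with Oryza sativa as the target, tested at 10 uM; a lower number here means a stronger effect, a higher number a weaker effect of the compound at the concentration tested:
compound 1, `Cc1ccc(NC(=O)N[C@H](C)c2ccccc2)cc1`, gives 64%
compound 2, `Cc1ccc(NC(=O)N[C@@H](C)c2ccccc2)cc1`, gives 100%
compound 3, `CCc1cccc(NC(=O)N[C@@H](C)c2ccccc2)c1`, gives 86%

Compound 2 stands at the highest number of the three, which in this assay means the weakest effect; compound 3 is the nearest to it and compound 1 the furthest. Among the compounds with values here, the one step that can be read within the set is the step of a number 36 percentage points higher from compound 1 to compound 2 (beyond the scatter), a large shift that rests only on (the fact that compounds 1 and 2 differ only in the configuration as drawn). Within the data shown here, compound 3 differs from compound 2 in more than one place, so no single step is drawn between them; their two numbers simply stand as given.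

Compound 4, `CCCCCCc1ccc(NC(=O)N[C@@H](C)c2ccccc2)cc1`, is not yet measured. It differs from compound 2 by pentyl in place of hydrogen on a saturated chain carbon bound to an aromatic carbon. Among the measured compounds shown here, neither the configuration step nor the pair of compound 2 and compound 3 involves a chain of this kind, so no measured step speaks to the size or direction of the change; the series carries no direct precedent for it. In this assay the step of a number 15 percentage points lower from compound 2 to compound 4 (beyond the scatter) is therefore expected with wide uncertainty, and a number either side of compound 2 cannot be excluded. Compound 4 is estimated at 85%, in the range 55% to 100%.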

Compound 4, a percentage reported as activity, at one concentration (the size of the read-out at that concentration, not a potency): 99%
Compound 4: the middle estimate sits 14 percentage points below what was measured; measured number inside the range.
By their numbers in this assay, from the lowest: compound 1; then compound 3; then compounds 4 and 2 (each within the scatter of the next).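

In this assay, pentyl in place of hydrogen on a saturated chain carbon bound to an aromatic carbon gives a number 1 percentage points lower from compound 2 to compound 4 (within the scatter), so methyl and hexyl at this place cannot be told apart by their numbers. Within the data shown here, this is the first reading at this place, as the only earlier step concerned configuration alone, and it holds only for the configuration drawn in compound 2 and compound 4. Nothing available bears on the reason the two numbers stand so close.

On these data alone, it remains open whether the same difference, methyl to hexyl, would also leave the number in place on the opposite configuration, that of compound 1, whose number lies well apart from that of compound 2. Also open, as far as these compounds go, are chains of other lengths at this place, such as propyl or octyl, and chains that carry an amine or a carboxylic acid, which would test whether anything at this place can move the number beyond the scatter.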